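This account rests on a few compounds, and the source may have more. Where it says the series, first, only, none or still open, it means among the compounds named here.

Measured compounds:
compound 1 `COc1cc(-c2nnc3c(OCC(F)(F)F)cc(-c4ccc5[nH]ccc5c4)cn23)cc(OC)c1OC`, 900 nM
compound 2 `COc1cc(-c2nnc3c(OC)cc(-c4ccc5c(ccn5C)c4)cn23)cc(OC)c1OC`, 33 nM

In a functional assay on HCT-116 cells (Homo sapiens) for antiproliferative activity, read by MTT assay, with a stated time of 48 h (on this read-out higher numbers stand for weaker inhibition and lower numbers for stronger inhibition), compound 2 gives 33 nM, the lowest of the two numbers recorded. Compound 1 gives 900 nM, a gap well beyond the scatter, but the two structures differ in more than one place, so the gap cannot be assigned to a single change. Compound 3 `COc1cc(-c2nnc3c(OCC(F)(F)F)cc(-c4ccc5c(ccn5C)c4)cn23)cc(OC)c1OC` arises from compound 2 by one change: trifluoromethyl in place of hydrogen on a saturated chain carbon bound to an oxygen on an aromatic ring. Going by the values given here, no measured pair isolates this change on its own. Compound 3 is expected to give 100 nM, between 30 nM and 400 nM, the estimated step of a 3.0-fold higher number from compound 2 to compound 3 (0.48 log units; beyond the scatter) being a moderate loss in this assay.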

Compound 3, half-maximal inhibitory concentration: 483 nM
Estimate against measurement, compound 3: 4.8-fold (0.68 log units) below; the whole stated range lies below it.
By their numbers in this assay, from the lowest: compound 2; then compounds 3 and 1 (each within the scatter of the next).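

In this assay, going from methoxy to 2,2,2-trifluoroethoxy is a large loss, with a 15-fold higher number from compound 2 to compound 3 (1.17 log units; beyond the scatter), so this position does not tolerate this change. Methyl in place of hydrogen on an aromatic nitrogen, with a 1.9-fold lower number from compound 1 to compound 3 (0.27 log units; within the scatter), has no effect that can be told from the scatter when 2,2,2-trifluoroethoxy is present. Nothing measured here accounts for the loss.

The compounds shown leave open how ethoxy, a longer chain or an amine would fare at this oxygen. They also leave open whether methyl on the aromatic nitrogen matters as little when methoxy is present.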